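Swapping methyl for chloro on the aryl of compound 1

This account rests on a few compounds, and the source may have more. Where it says the series, first, only, none or still open, it means among the compounds named here.

Compound 1, `C=C(Br)C(=O)Nc1cccc(-c2cn3nc(-c4ccc(C)cc4)sc3n2)c1`, is the stronger of two measured compounds in a functional assay on L1210 cells (Mus musculus) for inhibition, read by cell counting, with a stated time of 2 days; a higher number here means a weaker inhibitor, a lower number a stronger inhibitor: compound 1 gives 920 nM, while compound 2, `COc1ccc(-c2csc3nc(-c4cccc(N)c4)cn23)cc1`, gives 19000 nM in this assay, a gap beyond the usual scatter. Compound 3, `C=C(Br)C(=O)Nc1cccc(-c2cn3nc(-c4ccc(Cl)cc4)sc3n2)c1`, has not yet been measured. It differs from compound 1 by one change: chloro in place of methyl on an aromatic carbon. Among the compounds with values here, since no measured pair shows this change, the expected step from compound 1 to compound 3 in this assay is small, estimated as a 1.0-fold lower number from compound 1 to compound 3 (0.01 log units; within the scatter), with no clear direction beyond the scatter. Compound 3 is therefore expected to give about 900 nM, within the range 400 nM to 2000 nM.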

Compound 3, half-maximal inhibitory concentration: 1400 nM
For compound 3 the middle estimate is 1.6-fold (0.19 log units) below the measured one; the measured number falls inside the stated range.
By their numbers in this assay, from the lowest: compounds 1 and 3 (each within the scatter of the next); then compound 2.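

Within the data shown here, changing 4-methylphenyl to 4-chlorophenyl in this assay gives a 1.5-fold higher number from compound 1 to compound 3 (0.18 log units; within the scatter) and is the first direct reading of a change at this position. At this carbon, chloro and methyl therefore cannot be told apart in this measurement, and neither compound 1 nor compound 3 can be ranked above the other. Nothing measured here explains why the two groups read alike.

From the compounds shown here alone, whether another group on this carbon, such as an amine, a carboxylic acid or a longer chain, would move the number beyond the scatter stays open. So does whether this swap would read the same with a different group on the other aromatic ring.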